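Sulfur-linked ring swap: compound 3 to compound 4

This account rests on a few compounds, and the source may have more. Where it says the series, first, only, none or still open, it means among the compounds named here.

In a functional assay on MCF7 cells (Homo sapiens) for inhibition, read by MTT assay, with a stated time of 72 h (on this read-out lower numbers stand for stronger inhibition and higher numbers for weaker inhibition), compound 1 (`FC(F)(F)c1ccc(CSc2nc(Sc3ncccn3)cc(C(F)(F)F)n2)cc1`) gives > 50000 nM, which is a limit of the assay. Compound 2 (`FC(F)(F)c1ccc(CSc2nc(Sc3nnnn3-c3ccccc3)cc(C(F)(F)F)n2)cc1`) reads 39500 nM. Compound 3 (`FC(F)(F)c1ccc(CSc2nc(Sc3nncs3)cc(C(F)(F)F)n2)cc1`) reads 8810 nM, the lowest number of the three.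

Compound 4 (`FC(F)(F)c1ccc(CSc2nc(SC3=NCCS3)cc(C(F)(F)F)n2)cc1`) keeps the shared core and changes only the group on a sulfur: a group of 5 heavy atoms (3 carbon, 1 nitrogen, 1 sulfur; one five-membered non-aromatic ring with 2 hetero atoms) in place of a group of 5 heavy atoms (2 carbon, 2 nitrogen, 1 sulfur; one five-membered aromatic ring with 3 hetero atoms), on a sulfur. The measured steps that bear on this change all exchange the group at that same place. They are a 4.5-fold lower number from compound 2 to compound 3 (0.65 log units; beyond the scatter) and an at least 5.6-fold lower number from compound 1 to compound 3 (0.75 log units; beyond the scatter), while an at least 1.2-fold lower number from compound 1 to compound 2 (0.10 log units; that floor lies within the scatter) separates the two other groups. No non-aromatic ring has been measured at this place. Both other groups give higher numbers than the 1,3,4-thiadiazol-2-yl of compound 3, as a 4.5-fold lower number from compound 2 to compound 3 (0.65 log units; beyond the scatter) shows, so a modest rise is expected in this assay when that group leaves. The upper side is bounded by the limit of > 50000 nM in this assay, at which 1 of the 3 values shown sits.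

The expected change is a 2.3-fold higher number from compound 3 to compound 4 (0.36 log units; beyond the scatter).

Compound 4 is estimated at 20000 nM, with an expected range of 6000 nM to 50000 nM.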

Compound 4, half-maximal inhibitory concentration: 44900 nM
Compound 4: middle estimate off by 2.2-fold (0.35 log units), on the low side; low and high end bracket the measured number.
By their numbers in this assay, from the lowest: compound 3; then compounds 2 and 4 (each within the scatter of the next). At a limit, above all of these: compound 1.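

In this assay, the first non-aromatic ring at this place gives a 5.1-fold higher number from compound 3 to compound 4 (0.71 log units; beyond the scatter), although the leaving and entering groups have equal heavy-atom counts, so that count alone does not set the number here. The much larger 1-phenyl-1H-tetrazol-5-yl group and the new ring cannot be told apart, with a 1.1-fold higher number from compound 2 to compound 4 (0.06 log units; within the scatter), and among the compounds with a measured number only the 1,3,4-thiadiazol-2-yl of compound 3 stands apart. Compound 1 stands at a limit of the assay, so an at least 1.1-fold lower number from compound 1 to compound 4 (0.04 log units; that floor lies within the scatter) gives no order for that pair: the limit of > 50000 nM in this assay, at which 1 of the 4 values shown sits.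

The compounds shown leave open whether the gap between compound 3 and compound 4 follows the loss of the aromatic ring or the change in ring atoms. A thiazol-2-yl group, an aromatic ring with the same ring atoms as the entering group, would separate the two.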